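Ethoxy to trifluoromethoxy: working notes on compound 3

The source may report more compounds than this note shows. Statements on the series, on what has been measured and on what is new or still open speak of the compounds shown alone.

Values so far in a functional assay on SEM cells (Homo sapiens) for inhibition, read by MTT assay, with a stated time of 72 h; on this read-out lower numbers stand for stronger inhibition and higher numbers for weaker inhibition:
- compound 1 `C=C(Br)C(=O)Nc1cccc(/C=C/C(=O)Nc2ccc(F)cc2)c1` gives 8400 nM
- compound 2 `C=C(Br)C(=O)Nc1cccc(/C=C/C(=O)Nc2ccc(OCC)cc2)c1` gives 180 nM

Compound 2 holds the lower of the two numbers and is the stronger inhibitor of this pair. The next structure is compound 3 `C=C(Br)C(=O)Nc1cccc(/C=C/C(=O)Nc2ccc(OC(F)(F)F)cc2)c1`, which differs from compound 2 by trifluoromethyl in place of ethyl on an oxygen on an aromatic ring and so carries trifluoromethyl in place of ethyl on an oxygen on an aromatic ring. Among the measured compounds shown here, only one measured step bears on this change: a 47-fold lower number from compound 1 to compound 2 (1.67 log units; beyond the scatter), a large step with ethoxy in place of fluoro on an aromatic carbon. That single step shows that this group can move the number strongly, but it sets no trend for a change on the oxygen. Compound 3 keeps the oxygen, so a shift toward a higher number in this assay is expected, smaller than that large step. The expected step is a 3.3-fold higher number from compound 2 to compound 3 (0.52 log units; beyond the scatter) on this estimate. For compound 3 the estimated value is 600 nM with an expected range of 150 nM to 3000 nM in this read-out.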

Compound 3, half-maximal inhibitory concentration: 19300 nM
For compound 3 the middle estimate is 32-fold (1.51 log units) below the measured one; the whole stated range lies below it.
By their numbers in this assay, from the lowest: compound 2; then compound 1; then compound 3.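

In this assay the group on the oxygen proves decisive, with a 110-fold higher number from compound 2 to compound 3 (2.03 log units; beyond the scatter) and the oxygen itself unchanged, so keeping that atom does not keep the low number that ethoxy gave. Trifluoromethoxy also fails to match fluoro on the aromatic carbon, with a 2.3-fold higher number from compound 1 to compound 3 (0.36 log units; beyond the scatter) as a modest step that is still beyond the scatter, so the oxygen alone does not account for the strength of compound 2. No measurement here explains either step, and their origin remains unassigned.

The compounds shown leave open how much of the ethyl group is needed, since neither a shorter group such as methyl nor a longer chain such as propyl on the oxygen appears among them. They also leave open whether an amine in place of the ethoxy would hold the number of compound 2.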